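A few compounds are considered here, and "the series" means these few. Any claim that something is new, unique, unknown or untested is made for them only; others in the source may bear on it.

Measured in a functional assay on DLD-1 cells (Homo sapiens) for inhibition, read by luminescence, with a stated time of 3 days; on this read-out higher numbers stand for weaker inhibition of growth and lower numbers for stronger inhibition of growth:
- compound 1 `CC(C)C1=C(C(=O)N2[C@H](C)CC[C@H]2C(=O)N2CCN(C)CC2)SC2=N[C@@](C)(c3ccc(Cl)cc3)[C@@H](c3ccc(Cl)cc3)N21`: 9000 nM
- compound 2 `CC[C@@H]1CC[C@@H](C(=O)N2CCN(C)CC2)N1C(=O)C1=C(C(C)C)N2C(=N[C@@](C)(c3ccc(Cl)cc3)[C@H]2c2ccc(Cl)cc2)S1`: 4000 nM

Of these two, compound 1 has the higher number, and so the weaker inhibition of growth. Compound 3 `CC(=O)N1CCN(C(=O)[C@@H]2CC[C@@H](C)N2C(=O)C2=C(C(C)C)N3C(=N[C@@](C)(c4ccc(Cl)cc4)[C@H]3c3ccc(Cl)cc3)S2)C[C@@H]1C` keeps the core of compound 1 and changes one group on a carbonyl carbon: a group of 10 heavy atoms (7 carbon, 2 nitrogen, 1 oxygen; one six-membered non-aromatic ring with 2 hetero atoms) in place of a group of 7 heavy atoms (5 carbon, 2 nitrogen; one six-membered non-aromatic ring with 2 hetero atoms), on a carbonyl carbon. Among the measured compounds shown here, the only measured step is modest, a 2.3-fold lower number from compound 1 to compound 2 (0.35 log units; beyond the scatter), and it concerns a different change, so it gives no direct guide here. No step beyond the scatter is therefore expected in this assay. The expected outcome is a 1.1-fold higher number from compound 1 to compound 3 (0.05 log units; within the scatter). For compound 3 the estimated value is 10000 nM, with an expected range from 4000 nM to 30000 nM.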

Compound 3, concentration for 50% growth inhibition: 5200 nM
Compound 3: middle estimate off by 1.9-fold (0.28 log units), on the high side, within the range that was stated.
By their numbers in this assay, from the lowest: compounds 2, 3 and 1 (each within the scatter of the next, the first and the last beyond it).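

In this assay, the group of 10 heavy atoms on the carbonyl carbon, in place of 4-methylpiperazin-1-yl, gives a 1.7-fold lower number from compound 1 to compound 3 (0.24 log units; within the scatter), so the step cannot be told apart from repeat-measurement noise. This position therefore takes a larger group, with a double bond outside aromatic rings and a defined stereocentre, without a clear shift in growth inhibition. No available evidence explains this result. The compounds shown leave open how a morpholine ring or an open-chain dimethylamino group would behave on this carbonyl carbon.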